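Bromo in place of hydrogen on compound 2

The source may hold more compounds than are shown below. What is called first, only, known or untested is meant among the compounds shown, and "the series" means these compounds.

In a functional assay on SW480 cells (Homo sapiens) for antiproliferative activity, read by MTT assay, with a stated time of 48 h (a lower number here means a stronger inhibitor, a higher number a weaker inhibitor), compound 2 (`CCCCCCC(CCO)n1cnc2c(Cl)ncnc21`) gives 16700 nM. Compound 1 (`CCCCCC(CCO)n1c(Br)nc2c(Cl)ncnc21`), which carries bromo, gives 23800 nM, within the scatter of compound 2. Compound 3 (`CCCCCCC(CCO)n1cnc2c(OC)ncnc21`) is reported only as a limit, > 50000 nM. Among the compounds with values here, the one measured step, an at least 2.9-fold higher number from compound 2 to compound 3 (0.47 log units; beyond the scatter), is methoxy in place of chloro, a different exchange, and bears only weakly here. Compound 4 (`CCCCCCC(CCO)n1c(Br)nc2c(Cl)ncnc21`) is bromo in place of hydrogen on an aromatic carbon. With compound 1 at 23800 nM as the only bromo reference, no shift beyond the scatter is expected in this assay, in either direction. The expected step is a 1.1-fold higher number from compound 2 to compound 4 (0.06 log units; within the scatter). For compound 4 the estimate is 19000 nM, with an expected range of 8500 nM to 42000 nM.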

Compound 4, half-maximal inhibitory concentration: 14100 nM
For compound 4 the middle estimate is 1.3-fold (0.13 log units) above the measured one, and the stated range covers the measured number.
By their numbers in this assay, from the lowest: compounds 4, 2 and 1 (each within the scatter of the next). At a limit, above all of these: compound 3.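

In this assay, the aromatic carbon between two ring nitrogen atoms carries bromo in place of hydrogen with no step beyond the scatter: a 1.2-fold lower number from compound 2 to compound 4 (0.07 log units; within the scatter). The chain comparison also stays within the scatter, with a 1.7-fold lower number from compound 1 to compound 4 (0.23 log units; within the scatter), so methyl in place of hydrogen on that saturated chain carbon does not separate this pair. Nothing shown here speaks to why the bromo exchange leaves the number within the scatter.

From the compounds shown here alone, whether an amine or a phenyl ring at this position would stay in the same range remains open. So does the effect of bromo alongside methoxy, since compound 3 is known only as a limit.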